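The source may report more compounds than this note shows. Statements on the series, on what has been measured and on what is new or still open speak of the compounds shown alone.

Compound 1 `COc1ccc(/C=C2/S/C(=N/c3ccccc3)N(Cc3ccncc3)C2=O)cc1`: 19100 nM
Compound 2 `O=C1/C(=C\c2ccc([N+](=O)[O-])cc2)S/C(=N/c2ccccc2)N1Cc1ccncc1`: 18900 nM
Compound 3 `COc1ccc(OC)c(/C=C2/S/C(=N/c3ccccc3)N(Cc3ccncc3)C2=O)c1`: 35800 nM

All three values come from a functional assay on HepG2 cells (Homo sapiens) for cytotoxicity, read by MTT assay, with a stated time of 48 h; on this read-out higher numbers stand for weaker inhibition and lower numbers for stronger inhibition. The compounds share one core and differ only in the aromatic group on a double-bonded chain carbon bound to a double-bonded ring carbon. Compound 3, at 35800 nM, cannot be separated from the other two, as the measured steps to it are a 1.9-fold higher number from compound 1 to compound 3 (0.27 log units; within the scatter) and a 1.9-fold higher number from compound 2 to compound 3 (0.28 log units; within the scatter). The remaining step at this group, a 1.0-fold lower number from compound 1 to compound 2 (0.00 log units; within the scatter), is no larger.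

Compound 4 `Cc1ccc(/C=C2/S/C(=N/c3ccccc3)N(Cc3ccncc3)C2=O)s1` has not yet been measured. It differs from compound 3 by one change: 5-methylthiophen-2-yl in place of 2,5-dimethoxyphenyl on a double-bonded chain carbon bound to a double-bonded ring carbon. In words, 5-methylthiophen-2-yl replaces 2,5-dimethoxyphenyl at that same place.

All three measured steps concern this place, and all stay within the scatter, so no step beyond the scatter is expected in this assay. Among the measured compounds shown here, still, no measured compound carries a five-membered aromatic ring here, so the data offer only indirect guidance and the range should stay wide. The estimated step is a 1.4-fold lower number from compound 3 to compound 4 (0.16 log units; within the scatter), which would be a small one. For compound 4 the estimated value is 25000 nM, with an expected range from 11000 nM to 55000 nM.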

Compound 4, half-maximal inhibitory concentration: 23100 nM
Beside the measured number, compound 4's estimate is 1.1-fold (0.03 log units) above it, within the range that was stated.
By their numbers in this assay, from the lowest: compounds 2, 1, 4 and 3 (each within the scatter of the next).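

Among the compounds shown here, until this result, every group at this place, on a double-bonded chain carbon bound to a double-bonded ring carbon, was a six-membered aromatic ring of carbon only, whereas 5-methylthiophen-2-yl brings a five-membered aromatic ring with 1 hetero atom and fewer heavy atoms than 2,5-dimethoxyphenyl. In this assay, this different ring stays within the scatter of all three earlier compounds (a 1.5-fold lower number from compound 3 to compound 4 (0.19 log units; within the scatter); a 1.2-fold higher number from compound 2 to compound 4 (0.09 log units; within the scatter); a 1.2-fold higher number from compound 1 to compound 4 (0.08 log units; within the scatter)), so among these four compounds neither the size of the aromatic ring nor the sulfur atom it contains separates one compound from another. No supporting evidence bears on this result, so the data give no explanation for it.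

These compounds leave open whether any group at this place could move the number beyond the scatter, since all four carry an aromatic ring there and none carries a carboxylic acid, an amine or a longer alkyl chain in its place. Going by these compounds, the rest of the shared core stays the same throughout, so the effect of changing any other part of it also remains unknown.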